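The source may report more compounds than this note shows. Statements on the series, on what has been measured and on what is new or still open speak of the compounds shown alone.

Measured compounds in the series:
- compound 1, `Cc1nc(S(C)(=O)=O)ccc1Oc1ncnc(OC2CCN(C(=O)OC(C)C)CC2)c1F`: 142 nM
- compound 2, `Cc1nc(S(C)(=O)=O)ccc1Oc1ncnc(OC2CCN(C(=O)O[C@@H](C)C(F)(F)F)CC2)c1F`: 109 nM
- compound 3, `CCC1(OC(=O)N2CCC(Oc3ncnc(Oc4ccc(S(C)(=O)=O)nc4C)c3F)CC2)CC1`: 333 nM

All three values come from a functional assay on isolated protein for inhibition of Glucose-dependent insulinotropic receptor (Rattus norvegicus), read by HTRF and cAMP accumulation; a lower number here means that less compound is needed, a higher number that more compound is needed for the effect. Compound 1 gives the second highest number of the three; its nearest neighbour is compound 2, with a 1.3-fold lower number from compound 1 to compound 2 (0.11 log units; within the scatter), a gap that says nothing about order. Compound 3 is the furthest from it, a 2.3-fold higher number from compound 1 to compound 3 (0.37 log units; beyond the scatter), and compound 3 also stands apart from compound 2, a 3.1-fold higher number from compound 2 to compound 3 (0.49 log units; beyond the scatter).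

The next compound, compound 4, `Cc1nc(S(C)(=O)=O)ccc1Oc1ncnc(OC2CCN(C(=O)SC(C)(C)C)CC2)c1F`, differs from compound 1 in one place: (tert-butyl)sulfanyl in place of isopropoxy on a carbonyl carbon. Both the group that leaves and the group that enters sit on the same carbonyl carbon, so the three measured steps, which all vary the group on an oxygen next to a carbonyl group, are the only ones that bear on this change. Two of them, from compound 1 to compound 2 and from compound 1 to compound 3, show that small changes at this position move the number either not at all or modestly upward. Going by the values given here, no measured step exchanges the oxygen itself for sulfur, so that part of the change is uncharted.

Expectation for compound 4 in this assay: a modest shift at most, a 1.4-fold higher number from compound 1 to compound 4 (0.15 log units; within the scatter), with the estimate 200 nM and a range from 90 nM to 450 nM.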

Compound 4, half-maximal effective concentration: 30.7 nM
For compound 4 the middle estimate is 6.5-fold (0.81 log units) above the measured one, and the stated range ends above it.
By their numbers in this assay, from the lowest: compound 4; then compounds 2 and 1 (each within the scatter of the next); then compound 3.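

In this assay, this carbonyl carbon proves more responsive than the earlier changes on the oxygen suggested: (tert-butyl)sulfanyl in place of isopropoxy gives a 4.6-fold lower number from compound 1 to compound 4 (0.67 log units; beyond the scatter), the first step away from compound 1 that lowers the number beyond the scatter. The same group also stands clear of the other two substituents on this carbon, with a 3.6-fold lower number from compound 2 to compound 4 (0.55 log units; beyond the scatter) and an 11-fold lower number from compound 3 to compound 4 (1.04 log units; beyond the scatter), so compound 4 has the lowest number of the four, and the largest of these steps spans the whole range seen so far in the series. No measurement at hand bears on what lies behind this shift.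

The change replaces the oxygen with sulfur and the isopropyl with a tert-butyl in a single step, so the compounds shown do not say which part carries the shift, or whether the two parts depend on each other. Tert-butoxy and isopropylsulfanyl on the same carbonyl carbon would separate the two parts, while a tert-butylamino group would show whether the number also responds to nitrogen in that place.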